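From methoxy to chloro in an antiproliferative series

The source may hold more compounds than are shown below. What is called first, only, known or untested is meant among the compounds shown, and "the series" means these compounds.

Compound 1 `CN1CCN(c2ccc(S(=O)(=O)Oc3cccc(Cl)c3)cc2)C1=O` gives 1600 nM
Compound 2 `CN1CCN(c2ccc(S(=O)(=O)Oc3cccc(Br)c3)cc2)C1=O` gives 1300 nM
Compound 3 `COc1ccc(OS(=O)(=O)c2ccc(N3CCN(C)C3=O)cc2)cc1` gives > 100000 nM (a limit)

These values come from a functional assay on M21 cells (Homo sapiens) for antiproliferative activity, read by sulforhodamine B assay, with a stated time of 48 h; a lower number here means a stronger inhibitor, a higher number a weaker inhibitor. Compound 3 is reported only as a limit, > 100000 nM, and not as a number. Compound 4 `CN1CCN(c2ccc(S(=O)(=O)Oc3ccc(Cl)cc3)cc2)C1=O` differs from it in one place, with chloro in place of methoxy on an aromatic carbon, para to a large group (chloro in place of methoxy on an aromatic carbon). Going by the values given here, two measured steps bear on this change, both large: an at least 62-fold higher number from compound 1 to compound 3 (1.79 log units; beyond the scatter) and an at least 76-fold higher number from compound 2 to compound 3 (1.88 log units; beyond the scatter). Each ends at the 4-methoxyphenyl group, so removing that group is expected to give a large move to a lower number in this assay. The step is estimated as an at least 20-fold lower number from compound 3 to compound 4 (1.30 log units; beyond the scatter). For compound 4 the expected value is 5000 nM, within an estimated range of 1200 nM to 30000 nM.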

Compound 4, half-maximal inhibitory concentration: 43000 nM
Estimate against measurement, compound 4: 8.6-fold (0.93 log units) below; measured number outside the range, above it.
By their numbers in this assay, from the lowest: compounds 2 and 1 (each within the scatter of the next); then compound 4. At a limit, above all of these: compound 3.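

Compound 3 is reported only at a limit: the limit of > 100000 nM in this assay, at which 1 of the 4 values shown sits. Chloro in place of methoxy at this position still gives an at least 2.3-fold lower number from compound 3 to compound 4 (0.36 log units; beyond the scatter), so the change does lower the number, though the full size of the step stays unknown. Chloro here does not match the earlier compounds, with a 27-fold higher number from compound 1 to compound 4 (1.43 log units; beyond the scatter) and a 33-fold higher number from compound 2 to compound 4 (1.52 log units; beyond the scatter), so the 4-chlorophenyl group sits well short of the 3-chlorophenyl and 3-bromophenyl groups. Going by these compounds, whether an amine or a carboxylic acid in this place would give a lower number than chloro stays open.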